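Chloro to Amino on a Dichloropurine Benzyl Series

A few compounds are considered here, and "the series" means these few. Any claim that something is new, unique, unknown or untested is made for them only; others in the source may bear on it.

Measured compounds:
- compound 1 `ClCc1ccccc1Cn1cnc2c(Cl)nc(Cl)nc21` — 720 nM
- compound 2 `Nc1nc(Cl)c2ncn(Cc3ccc(CCl)cc3)c2n1` — 12300 nM
- compound 3 `ClCc1cccc(Cn2cnc3c(Cl)ncnc32)c1` — 2340 nM

Of the compounds shown here, three built on the same fused core have been tested in a functional assay on SN12C cells (Homo sapiens) for cytotoxicity, read by sulforhodamine B assay, with a stated time of 48 h; on this read-out lower numbers stand for stronger inhibition of growth and higher numbers for weaker inhibition of growth. Compound 1 gives 720 nM, compound 3 gives 2340 nM and compound 2 gives 12300 nM. Compound 1 therefore stands with the lowest number of the three, and its gaps to both compound 3 and compound 2 lie beyond the scatter, so it is the strongest inhibitor of growth in this small set. Within the data shown here, no pair of these three differs in only one place, so no single step can be isolated among them; compound 2, the weakest, carries an amino group but also a different position of the chloromethyl arm, and what its value shows cannot be split between the two.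

Compound 4 `Nc1nc(Cl)c2ncn(Cc3ccccc3CCl)c2n1` is the next compound, obtained from compound 1 by one change: amino in place of chloro on an aromatic carbon. Among the measured compounds shown here, with no one-place step to lean on, the direction is read cautiously from compound 2, whose value of 12300 nM is the only one with an amino group here. Compound 4 is estimated at 4000 nM, with a range from 1000 nM to 16000 nM. The expected step of a 5.6-fold higher number from compound 1 to compound 4 (0.74 log units; beyond the scatter) would be a loss beyond the scatter.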

Compound 4, concentration for 50% growth inhibition: 2750 nM
Compound 4: the middle estimate sits 1.5-fold (0.16 log units) above what was measured, within the range that was stated.
By their numbers in this assay, from the lowest: compound 1; then compounds 3 and 4 (each within the scatter of the next); then compound 2.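

Among these compounds, for the first time the series has a step that changes one place only: in this assay, replacing chloro with amino on the aromatic carbon between two ring nitrogen atoms gives a 3.8-fold higher number from compound 1 to compound 4 (0.58 log units; beyond the scatter), a modest loss of growth inhibition. This shows that the chloro group at this carbon is not required for activity in the assay, since compound 4 still gives 2750 nM with amino in its place, although compound 1 remains the stronger of the pair. The change replaces a group with no hydrogen-bond donors or acceptors by one with a donor and an acceptor, but no available evidence accounts for the size of the step.

Going by these compounds, a single exchange at one carbon gives no trend, so it remains open how a methylamino group, a dimethylamino group or a methoxy group at the same carbon would compare with chloro and amino. On these data alone, it is also open whether the step from chloro to amino would have the same size with the chloromethyl arm placed as in compound 2 or compound 3.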